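The source may report more compounds than this note shows. Statements on the series, on what has been measured and on what is new or still open speak of the compounds shown alone.

Measured compounds:
compound 1, `COc1cc(Nc2nc3ccccc3nc2S(=O)(=O)c2ccccc2)cc(OC)c1`: 50 nM
compound 2, `Nc1ccc(Nc2nc3ccccc3nc2S(=O)(=O)c2ccccc2)cc1`: 8720 nM
compound 3, `COc1cc(Nc2nc3ccccc3nc2S(=O)(=O)c2ccc(Br)cc2)cc(OC)c1`: 2540 nM

These three were tested in a functional assay on HL-60 cells (Homo sapiens) for cytotoxicity, read by MTT assay, with a stated time of 72 h; on this read-out higher numbers stand for weaker inhibition and lower numbers for stronger inhibition. Compound 1 and compound 2 differ by 4-aminophenyl in place of 3,5-dimethoxyphenyl on a nitrogen on an aromatic ring, and this change gave a 170-fold higher number from compound 1 to compound 2 (2.24 log units; beyond the scatter). Compound 1 and compound 3 differ by bromo in place of hydrogen on an aromatic carbon, which gave a 51-fold higher number from compound 1 to compound 3 (1.71 log units; beyond the scatter). Both changes, made singly, weakened the compounds.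

Compound 4, `Nc1ccc(Nc2nc3ccccc3nc2S(=O)(=O)c2ccc(Br)cc2)cc1`, has not yet been measured. It differs from compound 3 by 4-aminophenyl in place of 3,5-dimethoxyphenyl on a nitrogen on an aromatic ring. This is the same change as that from compound 1 to compound 2, made at the same place, but now on the core of compound 3, which already carries the bromo group. Whether the two weakening changes add up cannot be known from the data shown. For compound 4 the expected step is a 31-fold higher number from compound 3 to compound 4 (1.50 log units; beyond the scatter), resting on the step of a 170-fold higher number from compound 1 to compound 2 (2.24 log units; beyond the scatter) seen on the other core, with room left for the two changes to overlap rather than add fully. Compound 4 is estimated at 80000 nM, with a range from 8000 nM to 500000 nM; it is also expected that the assay may report only a limit here.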

Compound 4, half-maximal inhibitory concentration: 730 nM
Beside the measured number, compound 4's estimate is 110-fold (2.04 log units) above it; the whole stated range lies above it.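

On the core of compound 3, which carries the bromo group, 4-aminophenyl in place of 3,5-dimethoxyphenyl gave a 3.5-fold lower number from compound 3 to compound 4 (0.54 log units; beyond the scatter), so the same change ran in the opposite direction to its step on the core of compound 1: the same change on two cores in this assay, a 170-fold higher number (2.24 log units; beyond the scatter) from compound 1 to compound 2 and a 3.5-fold lower number (0.54 log units; beyond the scatter) from compound 3 to compound 4, 610-fold (2.78 log units) apart, beyond the scatter of two such steps

Bromo in place of hydrogen reversed in the same way, with a 12-fold lower number from compound 2 to compound 4 (1.08 log units; beyond the scatter) once 4-aminophenyl was present: the same change on two cores in this assay, a 51-fold higher number (1.71 log units; beyond the scatter) from compound 1 to compound 3 and a 12-fold lower number (1.08 log units; beyond the scatter) from compound 2 to compound 4, 610-fold (2.78 log units) apart, beyond the scatter of two such steps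

Across these four compounds, then, the effect of each change depended on the other, so neither step could be carried to the other core as a fixed amount, but the data do not show why this happens or whether it extends beyond this pair of changes.

As far as these compounds go, it remains open whether the reversal is tied to the bromo group itself or to 4-aminophenyl in particular. A chloro or methyl group in place of the bromo group, or 4-hydroxyphenyl in place of 4-aminophenyl, would help to separate these possibilities.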